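This account rests on a few compounds, and the source may have more. Where it says the series, first, only, none or still open, it means among the compounds named here.

Measured compounds in a functional assay on MCF7 cells (Homo sapiens) for inhibition, read by XTT assay, with a stated time of 48 h; a lower number here means a stronger inhibitor, a higher number a weaker inhibitor:

Compound 1, `COc1ccc(C(=O)/C(=C/c2ccc(Cl)cc2Cl)CC(C)C)cc1`: in this assay compound 1 gives only a limit, > 100000 nM.
Compound 2, `COc1ccc(C(=O)/C(=C/c2ccc(C(F)(F)F)cc2)CC(C)C)cc1`: in this assay compound 2 gives only a limit, > 100000 nM.
Compound 3, `COc1ccc(C(=O)/C(=C/c2ccc(Cl)cc2Cl)CC2CCCCC2)cc1`: in this assay compound 3 gives only a limit, > 100000 nM.

All three measured values sit at the same assay limit, (the limit of > 100000 nM in this assay, at which 3 of the 3 values shown sit), so no ordering among compound 1, compound 2 and compound 3 can be drawn from them.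

Compound 1 and compound 3 share a core and differ in one place, (cyclohexyl in place of isopropyl on a saturated chain carbon bound to a double-bonded chain carbon). The step that the two limits leave unreadable from compound 1 to compound 3 is left unreadable by the two limits; its size is not known.

Compound 4, `COc1ccc(C(=O)/C(=C/c2ccc(C(F)(F)F)cc2)CC2CCCCC2)cc1`, is not yet measured. It stands to compound 2 as compound 3 stands to compound 1: the change is cyclohexyl in place of isopropyl on a saturated chain carbon bound to a double-bonded chain carbon, the same change at the same place. How the core of compound 2 differs from the core of compound 1 is not broken down here.

For the measured compounds named here, for compound 4 the step that the limit leaves unreadable from compound 2 to compound 4 is expected to be unreadable in the same way, since the one measured example of this change, from compound 1 to compound 3, gives only limits at both ends and compound 2 itself gives only a limit, > 100000 nM. Compound 4 is therefore expected to come out at about 150000 nM, most likely as a limit rather than a number, with a range of 50000 nM to 500000 nM.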

Compound 4, half-maximal inhibitory concentration: > 100000 nM
Compound 4 ended at the assay's limit (the forecaster's own chance of this, stated with the estimate: 85%); the middle value does not contradict the limit.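

No new step can be read from compound 2 to compound 4, as both ends are limits, and compound 1 and compound 3 are no more informative; the values share one ceiling: the limit of > 100000 nM in this assay, at which 4 of the 4 values shown sit.

The compounds shown leave open whether any member of this series reaches a measurable value in this assay, and whether cyclohexyl in place of isopropyl changes that value at all.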